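A few compounds are considered here, and "the series" means these few. Any claim that something is new, unique, unknown or untested is made for them only; others in the source may bear on it.

Compound 2 `COc1ccccc1NC(=O)CN1CCN(S(=O)(=O)N2CCC(C)CC2)CC1` sits at a limit of an assay on HEK293 cells for inhibition of potassium channel subfamily T member 1 (Homo sapiens), read by thallium flux (on this read-out higher numbers stand for weaker inhibition and lower numbers for stronger inhibition), rather than at a number: compound 2 gives > 10000 nM, which is the limit (the limit of > 10000 nM in this assay, at which 1 of the 3 values shown sits). Two related compounds do give numbers. Compound 1 `COc1ccc(F)cc1NC(=O)CN1CCN(S(=O)(=O)N2CCC(C)CC2)CC1` gives 4900 nM in this assay. Compound 3 `COc1ccc(Cl)cc1NC(=O)[C@@H](C)N1CCN(S(=O)(=O)N2CCC(C(F)(F)F)CC2)CC1` gives 3500 nM. Within the data shown here, the only measured single-point step is an at least 2.0-fold higher number from compound 1 to compound 2 (0.30 log units; that floor lies within the scatter), where removing a fluoro from an aromatic carbon moved the number from a value to the limit. Compound 4 `COc1ccc(C)cc1NC(=O)CN1CCN(S(=O)(=O)N2CCC(C)CC2)CC1` differs from compound 2 by methyl in place of hydrogen on an aromatic carbon, putting a substituent back where compound 1 also carries one. The expected step is an at least 1.6-fold lower number from compound 2 to compound 4 (0.22 log units; that floor lies within the scatter), a return toward the range of compound 1, though a limit remains possible. Compound 4 is therefore estimated at 6000 nM, between 2500 nM and 15000 nM.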

Compound 4, half-maximal inhibitory concentration: > 10000 nM
Compound 4 was reported as a limit (the forecaster's own chance of this, stated with the estimate: 40%); at least 1.6-fold (0.22 log units) between middle value and limit.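

With a methyl on this carbon, para to a methoxy group, compound 4 sits at a limit in this assay, so a substituent here does not by itself bring back a measurable number. Putting methyl in place of fluoro gives an at least 2.0-fold higher number from compound 1 to compound 4 (0.30 log units; that floor lies within the scatter), so the real gap between these two groups could be small or large. The step between the two unsubstituted and methyl compounds cannot be read, since both are limits: the limit of > 10000 nM in this assay, at which 2 of the 4 values shown sit.

As far as these compounds go, whether a nitrile or an amine on this carbon would give a number stays open.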